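Compound 2 to compound 4: methyl to ethyl

The source may report more compounds than this note shows. Statements on the series, on what has been measured and on what is new or still open speak of the compounds shown alone.

Values in a functional assay on A549 cells (Homo sapiens) for cytotoxicity, with a stated time of 60 h; on this read-out higher numbers stand for an effect only at larger amounts of compound and lower numbers for an effect already at smaller amounts
- compound 1 `CCN(CC)C(=O)c1c(NC(=O)c2cncs2)sc2c1CCCC2` gives > 30000 nM (a limit of the assay, not a number)
- compound 2 `CCN(CC)C(=O)c1c(NC(=O)c2cccs2)sc2c1CC(C)CC2` gives 1000 nM
- compound 3 `CCN(CC)C(=O)c1c(NC(=O)c2cccs2)sc2c1CC(C)(C)CC2` gives 6000 nM
- compound 4 `CCC1CCc2sc(NC(=O)c3cccs3)c(C(=O)N(CC)CC)c2C1` is not yet measured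

Of the two actual numbers, compound 2 holds the lower at 1000 nM, and compound 3 holds the higher at 6000 nM. Compound 4 differs from compound 2 by methyl in place of hydrogen on a saturated chain carbon bound to a saturated ring carbon, which reads as methyl to ethyl. Within the data shown here, only one measured step bears on this change: methyl in place of hydrogen on a saturated ring carbon, a 6.0-fold higher number from compound 2 to compound 3 (0.78 log units; beyond the scatter). That step is modest and beyond the scatter, but it sits at a different place, so it is only a loose guide. A modest rise of similar or smaller size is therefore expected in this assay. The expected change is a 2.5-fold higher number from compound 2 to compound 4 (0.40 log units; beyond the scatter). For compound 4 the estimated value is 2500 nM, with an expected range of 700 nM to 10000 nM.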

Compound 4, half-maximal effective concentration: 12000 nM
Estimate against measurement, compound 4: 4.8-fold (0.68 log units) below; measured number outside the range, above it.
By their numbers in this assay, from the lowest: compound 2; then compounds 3 and 4 (each within the scatter of the next). At a limit, above all of these: compound 1.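

In this assay, lengthening the methyl on the saturated ring carbon to ethyl gives a 12-fold higher number from compound 2 to compound 4 (1.08 log units; beyond the scatter), a large step. Until now this position was known only from a second methyl on the saturated ring carbon, a 6.0-fold higher number from compound 2 to compound 3 (0.78 log units; beyond the scatter), a modest step, so the number also rises when the added methyl sits on the chain carbon, and in these two compounds the rise is larger there. Compound 4 still gives an actual number, and only compound 1 stands at a limit, which is not a number: the limit of > 30000 nM in this assay, at which 1 of the 4 values shown sits.

On these data alone, whether a propyl chain or a hydroxymethyl group on the saturated ring carbon would carry the rise further stays open. So does the value of the thiophene amide with only hydrogen at this carbon, which would show what the methyl of compound 2 itself contributes.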